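Swapping Trifluoromethyl for Chloro on a Diaryl Ether Acid

The compounds below may be only part of what the source reports. "The series", "measured", "known", "first", "only" and "open" are said of these compounds alone.

Compound 3 `O=C(O)CCc1ccc(Oc2ccc(C(F)(F)F)cc2Cl)cc1` gives 686 nM in a functional assay on CHO cells for agonist activity at Free fatty acid receptor 1 (Homo sapiens), read by FLIPR and calcium flux (a higher number here means that more compound is needed for the effect, a lower number that less compound is needed), the lowest of the three numbers recorded so far. Among the compounds with values here, its nearest neighbour is compound 2 `O=C(O)C(Cc1ccc(Oc2ccc(C(F)(F)F)cc2Cl)cc1)C(=O)O`, which gives 970 nM in this assay; the step of a 1.4-fold lower number from compound 2 to compound 3 (0.15 log units; within the scatter) is the only one-place change among the measured compounds. Furthest away is compound 1 `CC(CC(=O)O)c1ccc(Oc2ccc(Cl)cc2Cl)cc1`, which gives 2480 nM in this assay, a gap from compound 3 that lies beyond the scatter, though no single-place step connects these two.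

Compound 4 `O=C(O)CCc1ccc(Oc2ccc(Cl)cc2Cl)cc1` differs from compound 3 by chloro in place of trifluoromethyl on an aromatic carbon. Within the data shown here, no measured step bears on this change: the step of a 1.4-fold lower number from compound 2 to compound 3 (0.15 log units; within the scatter) concerns the acid chain, not the substituted ring. Among the measured compounds shown here, compound 1 carries the same pair of chloro groups as compound 4 but a different chain, so its value shows only that this ring pattern remains active. The expectation is therefore a step of a 1.3-fold higher number from compound 3 to compound 4 (0.12 log units; within the scatter), small and likely within the scatter. Compound 4 is estimated at 900 nM, with a range from 400 nM to 2500 nM.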

Compound 4, half-maximal effective concentration: 1360 nM
Beside the measured number, compound 4's estimate is 1.5-fold (0.18 log units) below it; the range from low to high includes it.
By their numbers in this assay, from the lowest: compounds 3, 2, 4 and 1 (each within the scatter of the next, the first and the last beyond it).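

The trifluoromethyl-to-chloro change on this aromatic carbon, para to a large group, now has a measured step of its own: a 2.0-fold higher number from compound 3 to compound 4 (0.30 log units; within the scatter) in this assay, so the two groups cannot be told apart at this position in this assay, even though the change takes away several heavy atoms. The chain also gains its first one-place reading with this ring pattern, a 1.8-fold lower number from compound 1 to compound 4 (0.26 log units; within the scatter), so removing the methyl group from the saturated chain carbon likewise leaves the number within the scatter. No measured evidence is available to explain either result.

Going by these compounds, it remains open whether a nitrile or a methoxy group on the same aromatic carbon would separate from these two groups. The compounds shown also leave open whether the methyl group on the chain would give a comparable step with trifluoromethyl on the ring.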